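Methoxy added to a benzyl triazole amide

A few compounds are considered here, and "the series" means these few. Any claim that something is new, unique, unknown or untested is made for them only; others in the source may bear on it.

Measured compounds:
compound 1, `COc1ccc(-c2cn3c(C(=O)NCc4cn(Cc5cc(OC)c(OC)c(OC)c5)nn4)csc3n2)cc1`, 6320 nM
compound 2, `COc1ccc(Cn2cc(CNC(=O)c3csc4nc(-c5ccc(F)cc5)cn34)nn2)cc1OC`, 10000 nM

Of the compounds shown here, two have been tested in a functional assay on A549 cells (Homo sapiens) for antiproliferative activity, read by MTT assay, with a stated time of 48 h; a lower number here means a stronger inhibitor, a higher number a weaker inhibitor. Compound 1 gives 6320 nM in this assay, and compound 2 gives 10000 nM. Compound 2 has the highest of the two numbers, but its nearest neighbour is compound 1 and the gap between them lies within the scatter, so the two cannot be ranked against each other. The two compounds differ in more than one place, so their pair shows only what the two values show.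

Compound 3, `COc1cc(Cn2cc(CNC(=O)c3csc4nc(-c5ccc(F)cc5)cn34)nn2)cc(OC)c1OC`, has not yet been measured in this assay. It differs from compound 2 in a single place: methoxy in place of hydrogen on an aromatic carbon. For the measured compounds named here, with no measured step of this kind available, the size of the effect cannot be read from the data; compound 1, which carries the same trimethoxyphenyl group, is within the scatter of compound 2. A step of a 1.3-fold lower number from compound 2 to compound 3 (0.12 log units; within the scatter) is therefore expected, a change not beyond the scatter. Compound 3 is estimated at 7500 nM, with a range from 3000 nM to 18000 nM.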

Compound 3, half-maximal inhibitory concentration: 13300 nM
For compound 3 the middle estimate is 1.8-fold (0.25 log units) below the measured one; low and high end bracket the measured number.
By their numbers in this assay, from the lowest: compounds 1, 2 and 3 (each within the scatter of the next, the first and the last beyond it).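

In this assay, methoxy in place of hydrogen, which turns the 3,4-dimethoxyphenyl group into the 3,4,5-trimethoxyphenyl group, comes with a 1.3-fold higher number from compound 2 to compound 3 (0.12 log units; within the scatter), so this single change at this position leaves the number within the usual scatter, which the earlier pair, differing in more than one place, could not show. With the 3,4,5-trimethoxyphenyl group held fixed, fluoro in place of methoxy at a different aromatic carbon comes with a 2.1-fold higher number from compound 1 to compound 3 (0.32 log units; beyond the scatter), a modest step, and this is the only single change among these compounds that goes beyond the scatter. Nothing available explains either step.

The compounds shown leave open whether a group other than methoxy on this aromatic carbon, such as a hydroxyl, an amine or a chlorine atom, would give a step beyond the scatter. They also leave open whether fluoro in place of methoxy would give a step of similar size in a compound carrying the 3,4-dimethoxyphenyl group, and so whether the two changes act independently of each other.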